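Ethoxy to propoxy on the shared core: working notes

This account rests on a few compounds, and the source may have more. Where it says the series, first, only, none or still open, it means among the compounds named here.

In an ADME assay on microsomes from liver (Mus musculus) for metabolic stability (on this read-out lower numbers stand for slow clearance and higher numbers for fast clearance), compound 1 (`CCCO[C@@H]1O[C@H](CNC(=O)c2ccc(S(N)(=O)=O)cc2)[C@H](O)[C@H](O)[C@H]1O`) gives 1.38 mL/min/kg and compound 2 (`CCCO[C@@H]1O[C@H](CNC(=O)c2ccc(S(N)(=O)=O)cc2)[C@@H](O)[C@H](O)[C@H]1O`) gives 1.53 mL/min/kg with a propoxy chain on the shared core. Compound 3 (`CCO[C@@H]1O[C@H](CNC(=O)c2ccc(S(N)(=O)=O)cc2)[C@@H](O)[C@H](O)[C@@H]1O`), with ethoxy, reads 1.48 mL/min/kg and sits within the scatter of compound 1 and compound 2 alike.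

Compound 4 (`CCCO[C@@H]1O[C@H](CNC(=O)c2ccc(S(N)(=O)=O)cc2)[C@@H](O)[C@H](O)[C@@H]1O`) has not been measured. Its structural change from compound 3 is methyl in place of hydrogen on a saturated chain carbon, two bonds along the chain from an oxygen on a saturated carbon (ethoxy to propoxy). Within the data shown here, the one measured step in the set is a 1.1-fold higher number from compound 1 to compound 2 (0.04 log units; within the scatter) and it lies within the scatter. Its bearing on the chain is only indirect, given the fact that compounds 1 and 2 differ only in the configuration as drawn with the propoxy chain unchanged. Among the measured compounds shown here, no measured step isolates ethoxy to propoxy on its own.

With compound 3 at 1.48 mL/min/kg and propoxy compound 2 at 1.53 mL/min/kg within the scatter of each other, no step beyond the scatter is expected in this assay and no direction is assigned. The expected change, a 1.0-fold higher number from compound 3 to compound 4 (0.01 log units; within the scatter) as estimated, stays inside the usual scatter of repeated measurements. Compound 4 is expected at 1.5 mL/min/kg with 1 mL/min/kg to 2.3 mL/min/kg as the estimated range.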

Compound 4, clearance: 1.42 mL/min/kg
The estimate for compound 4 lay 1.1-fold (0.02 log units) above the measured number; measured number inside the range.
By their numbers in this assay, from the lowest: compounds 1, 4, 3 and 2 (each within the scatter of the next).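

In this assay, ethoxy to propoxy on the shared core now has a direct reading, a 1.0-fold lower number from compound 3 to compound 4 (0.02 log units; within the scatter), so methyl in place of hydrogen on a saturated chain carbon, two bonds along the chain from an oxygen on a saturated carbon, stays within the scatter on this configuration. Earlier, the chain could be judged only indirectly, through compounds that shared the propoxy chain or through values set side by side. With propoxy held fixed, two further configuration steps, a 1.1-fold lower number from compound 2 to compound 4 (0.03 log units; within the scatter) and a 1.0-fold higher number from compound 1 to compound 4 (0.01 log units; within the scatter), also lie within the scatter, so the single configuration step seen before is now joined by two more, one of them at two stereocentres: the fact that compounds 1 and 4 differ only in the configuration as drawn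

On these data alone, the ethoxy to propoxy step has been read on one configuration only, so it remains open whether the same change stays within the scatter on the other configurations of the shared core. Also open, as far as these compounds go, is whether a longer chain such as butoxy, or a chain ending in an amine or a carboxylic acid, would stay within the scatter in this assay.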